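Swapping Dichlorophenyl for Dimethoxyphenyl on the Shared Core

This account rests on a few compounds, and the source may have more. Where it says the series, first, only, none or still open, it means among the compounds named here.

Three compounds were tested in a functional assay on MDA-MB-435 cells (Homo sapiens) for inhibition, read by sulforhodamine B assay, with a stated time of 48 h; on this read-out higher numbers stand for weaker inhibition of growth and lower numbers for stronger inhibition of growth. Compound 1 `Nc1cc(N)c2nc(-c3ccccc3)c(Oc3ccc(Cl)c(Cl)c3)nc2c1` gives 5010 nM. Compound 2 `CCOC(=O)[C@H](CCC(=O)O)NC(=O)c1ccc(CNc2nc3cc(N)cc(N)c3nc2-c2ccccc2)cc1` gives 66100 nM. Compound 3 `Nc1cc(N)c2nc(-c3ccccc3)c(NCc3ccc(Cl)c(Cl)c3)nc2c1` gives 2750 nM, the lowest of the three numbers; against compound 1 the gap lies within the usual scatter of repeated measurements, while against compound 2 it lies well beyond it.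

Compound 4 `COc1ccc(CNc2nc3cc(N)cc(N)c3nc2-c2ccccc2)cc1OC` has not been measured. It differs from compound 3 in one place: 3,4-dimethoxyphenyl in place of 3,4-dichlorophenyl on a saturated chain carbon bound to a nitrogen on an aromatic ring. For the measured compounds named here, no pair among the measured compounds isolates this change, so its effect in this assay is not documented here. The nearest guide is that compound 3 and compound 1, which share the 3,4-dichlorophenyl group but carry it through different linkers, sit close together.

For compound 4 in this assay a step no larger than the scatter is expected, leaning toward a weaker inhibition of growth, so that the expected step of a 1.8-fold higher number from compound 3 to compound 4 (0.26 log units; within the scatter) stays modest. Compound 4 is accordingly estimated at 5000 nM, with a range from 1500 nM to 17000 nM.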

Compound 4, concentration for 50% growth inhibition: 1950 nM
The estimate for compound 4 lay 2.6-fold (0.41 log units) above the measured number; the range from low to high includes it.
By their numbers in this assay, from the lowest: compounds 4, 3 and 1 (each within the scatter of the next, the first and the last beyond it); then compound 2.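

In this assay, for the compounds shown here, the only pair that isolates this change gives a 1.4-fold lower number from compound 3 to compound 4 (0.15 log units; within the scatter) and so does not separate 3,4-dimethoxyphenyl from 3,4-dichlorophenyl on a saturated chain carbon bound to a nitrogen on an aromatic ring. This position therefore accepts the exchange without a measurable shift on this read-out, even though the entering group has 10 heavy atoms and 2 hydrogen-bond acceptors, and the leaving group has 8 and 0. No measurement at hand bears on why the two groups read alike.

The compounds shown leave open whether an unsubstituted phenyl, or a phenyl carrying an amine or a carboxylic acid, would also read alike at this place. They also leave open whether a longer chain in place of the saturated chain carbon would keep the number where it stands.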